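The source may report more compounds than this note shows. Statements on the series, on what has been measured and on what is new or still open speak of the compounds shown alone.

Two compounds share one core and differ only in the ring on a saturated chain carbon bound to an amine nitrogen: compound 1 (`CCN(CCNC(=O)c1cc(Cl)c(N)cc1OC)Cc1ccccc1`) carries phenyl there, and compound 2 (`CCN(CCNC(=O)c1cc(Cl)c(N)cc1OC)Cc1ccoc1`) carries furan-3-yl. In a functional assay on the whole organism with Rattus norvegicus as the target (a higher number here means that more compound is needed for the effect, a lower number that less compound is needed), compound 1 gives 0.31 mg/kg and compound 2 gives 3 mg/kg, so compound 2 holds the higher of the two numbers. Within the data shown here, the only measured step is a 9.7-fold higher number from compound 1 to compound 2 (0.99 log units; beyond the scatter), which lies beyond the usual scatter.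

Compound 3 (`CCN(CCNC(=O)c1cc(Cl)c(N)cc1OC)Cc1ccccn1`) changes that ring again, with pyridin-2-yl in place of furan-3-yl on a saturated chain carbon bound to an amine nitrogen. The measured step bears on this only in part. Pyridin-2-yl has a six-membered aromatic ring like the phenyl of compound 1 (0.31 mg/kg), yet it holds a hetero atom in its ring like the furan-3-yl of compound 2 (3 mg/kg). Among the measured compounds shown here, no measured compound has a ring with nitrogen, so a move only part of the way back is expected. The expected change is a 3.0-fold lower number from compound 2 to compound 3 (0.48 log units; beyond the scatter) in this assay. The estimated value for compound 3 is 1 mg/kg, with a range from 0.3 mg/kg to 4 mg/kg.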

Compound 3, dose for half-maximal effect: 30 mg/kg
The estimate for compound 3 lay 30-fold (1.48 log units) below the measured number; the whole stated range lies below it.
By their numbers in this assay, from the lowest: compound 1; then compound 2; then compound 3.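

In this assay the ring at this position matters more than the earlier pair could show: pyridin-2-yl in place of furan-3-yl gives a 10-fold higher number from compound 2 to compound 3 (1.00 log units; beyond the scatter) and so moves further from phenyl, not back towards it, while pyridin-2-yl in place of phenyl gives a 97-fold higher number from compound 1 to compound 3 (1.99 log units; beyond the scatter) as the largest step of the set. Phenyl and pyridin-2-yl are both six-membered aromatic rings, so a matching ring size does not preserve the low dose of compound 1, and the five-membered furan-3-yl of compound 2 sits in the middle of the three, which means that the order does not follow ring size. No measurement here explains why the ring nitrogen of compound 3 comes with such a high dose.

Still open, from the compounds shown here alone, is whether the placement of the ring nitrogen matters, which pyridin-3-yl and pyridin-4-yl on the same carbon would test. Going by these compounds, it is also open whether another five-membered ring, such as thiophen-3-yl, or a substituted phenyl, such as 4-fluorophenyl, would stay close to phenyl or shift the dose as the heteroaromatic rings here do.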